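Lengthening the acyl chain of compound 2

This account rests on a few compounds, and the source may have more. Where it says the series, first, only, none or still open, it means among the compounds named here.

In a functional assay on MGC-803 cells (Homo sapiens) for inhibition, read by MTT assay, with a stated time of 48 h (on this read-out lower numbers stand for stronger inhibition and higher numbers for weaker inhibition), compound 1 `COCC(=O)N(Cc1ccc(OC)c(O)c1)c1cc(OC)c(OC)c(OC)c1` gives 79 nM, and compound 2 `COc1ccc(CN(C(=O)CO)c2cc(OC)c(OC)c(OC)c2)cc1O` gives 160 nM, the higher of the two numbers. Going by the values given here, the only measured step is a 2.0-fold higher number from compound 1 to compound 2 (0.31 log units; beyond the scatter). It is modest.

Compound 3 `COc1ccc(CN(C(=O)CCCCCl)c2cc(OC)c(OC)c(OC)c2)cc1O` differs from compound 2 as follows: 3-chloropropyl in place of hydroxy on a saturated chain carbon bound to a carbonyl carbon. This places 3-chloropropyl in place of hydroxy on a saturated chain carbon bound to a carbonyl carbon. Among the compounds with values here, only the one measured step bears on this change, and it is a smaller exchange, so it gives weak guidance on direction and size. A modest move towards a higher number is expected in this assay, although no chain of this kind has been measured. The expected change is a 2.2-fold higher number from compound 2 to compound 3 (0.34 log units; beyond the scatter). Compound 3 is estimated at 350 nM, with an expected range of 70 nM to 1500 nM.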

Compound 3, half-maximal inhibitory concentration: 540 nM
Beside the measured number, compound 3's estimate is 1.5-fold (0.19 log units) below it; the range from low to high includes it.
By their numbers in this assay, from the lowest: compound 1; then compound 2; then compound 3.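

In this assay, the exchange at the saturated chain carbon bound to a carbonyl carbon gives a 3.4-fold higher number from compound 2 to compound 3 (0.53 log units; beyond the scatter), so this position still reads in the assay with 3-chloropropyl in place of hydroxy, but the number rises even though the entering group has 0 hydrogen-bond donors. Set against the methoxy group, the same chain gives a 6.8-fold higher number from compound 1 to compound 3 (0.83 log units; beyond the scatter), which orders the three groups from the lowest number to the highest as methoxy, hydroxy and 3-chloropropyl. No measurement bears on why the number rises with this chain.

The compounds shown do not separate the length of the chain from the chlorine at its end. A plain butyl chain, a shorter chloroethyl chain or an amine at the chain end would bear on that question.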